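Swapping the Aryl Group on a Fused Core

This account rests on a few compounds, and the source may have more. Where it says the series, first, only, none or still open, it means among the compounds named here.

Compound 2 `CC(C)OC(=O)N1CCC(Oc2ncnc3c2CCN3c2ccc(C#N)cc2F)CC1`: 134%
Compound 1 `CC(C)(C)OC(=O)N1CCC(Oc2cccc3c2CCN3c2ccc(S(C)(=O)=O)cc2)CC1`: 92%
Compound 3 `CC(C)OC(=O)N1CCC(Oc2ncnc3c2CCN3c2ccc(-c3cccn3C)cc2F)CC1`: 44%

In a functional assay on CHO-K1 cells with Glucose-dependent insulinotropic receptor (Homo sapiens) as the target, read by a luciferase reporter, with a stated time of 5 h (a higher number here means a larger maximal response, a lower number a smaller maximal response), compound 2 gives 134%, the highest of the three values. Compound 1 gives 92% and compound 3 gives 44%, both beyond the scatter below compound 2. Compound 4 `Cc1cc(S(C)(=O)=O)ccc1N1CCc2c(OC3CCN(C(=O)OC(C)C)CC3)ncnc21` differs from compound 2 in one place: 2-methyl-4-(methylsulfonyl)phenyl in place of 4-cyano-2-fluorophenyl on a nitrogen on an aromatic ring in a ring. Among the measured compounds shown here, only one measured step changes the group at this position, and it was large: a number 90 percentage points lower from compound 2 to compound 3 (beyond the scatter). That shows the maximal response is sensitive to what sits on this nitrogen. Compound 1, which carries a methylsulfonyl group on a different core, also sits below compound 2. For the measured compounds named here, a drop is therefore expected, though smaller than the one to compound 3. Compound 4 is expected to give 95%, within 60% to 125%. The expected step is a number 39 percentage points lower from compound 2 to compound 4 (beyond the scatter).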

Compound 4, largest response reached (reported as percent of maximum), in percent of the reference or control that the assay uses: 80%
Compound 4: the middle estimate sits 15 percentage points above what was measured; measured number inside the range.
By their numbers in this assay, from the lowest: compound 3; then compound 4; then compound 1; then compound 2.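

Placing 2-methyl-4-(methylsulfonyl)phenyl on this nitrogen in place of 4-cyano-2-fluorophenyl gives a number 54 percentage points lower from compound 2 to compound 4 (beyond the scatter) in this assay, so a second, quite different aryl group also falls short of the nitrile-bearing one. Compound 4 at 80% still stands above compound 3 at 44%, so the size of the loss varies with the group that enters. No measurement shown here accounts for this loss.

On these data alone, the methyl and methylsulfonyl groups entered together, and their separate contributions remain open. Also open, as far as these compounds go, is whether an amine or a carboxylic acid in place of the nitrile would keep the response.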